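The source may hold more compounds than are shown below. What is called first, only, known or untested is meant among the compounds shown, and "the series" means these compounds.

Compound 1, `CC1=CC[C@@H]2[C@@H](O[C@H](c3ccc(F)cc3)OC2(C)C)[C@@H]1O`: 40%
Compound 2, `CC1=CC[C@@H]2[C@@H](O[C@H](c3ccc(Cl)cc3)OC2(C)C)[C@@H]1O`: 88%
Compound 3, `CC1=CC[C@@H]2[C@@H](O[C@H](c3ccc(Br)cc3)OC2(C)C)[C@@H]1O`: 33%

The three measured compounds share one core and differ only in the group on the aromatic ring. In a functional assay on the whole organism (Abdomen, strain albino) for inhibition, with Mus musculus as the target, in the writhing test, with stated times of 1 h and 8 min, at a dose of 10 mg/kg by the oral route (a lower number here means less inhibition, a higher number more inhibition at the dose given (going by the name of the read-out)), compound 2 gives 88%, compound 1 gives 40% and compound 3 gives 33%. Compound 3 stands lowest of the three numbers; its nearest neighbour lies within the scatter, a number 7 percentage points lower from compound 1 to compound 3 (within the scatter), while the furthest lies well beyond it, a number 55 percentage points lower from compound 2 to compound 3 (beyond the scatter). The change to compound 4, `CC1=CC[C@@H]2[C@@H](O[C@H](c3ccc([N+](=O)[O-])cc3)OC2(C)C)[C@@H]1O`, is nitro in place of bromo on an aromatic carbon. Among the measured compounds shown here, no measured step exchanges a halogen for a nitro group, so the halogen steps are the only guide: a number 48 percentage points higher from compound 1 to compound 2 (beyond the scatter) and a number 55 percentage points lower from compound 2 to compound 3 (beyond the scatter) were large, whereas a number 7 percentage points lower from compound 1 to compound 3 (within the scatter) stayed within the scatter. These numbers do not follow the size of the halogen, so a move in either direction is possible, and the estimate is kept wide. Compound 4 is expected to give about 45%, somewhere between 15% and 80%. This amounts to an expected a number 12 percentage points higher from compound 3 to compound 4 (beyond the scatter), modest and uncertain.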

Compound 4, a percentage reported as inhibition, in the whole organism at one dose (the size of the read-out at that dose, not a potency): 65%
The estimate for compound 4 lay 20 percentage points below the measured number; the range from low to high includes it.
By their numbers in this assay, from the lowest: compounds 3 and 1 (each within the scatter of the next); then compound 4; then compound 2.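

Nitro is the only group here that is not a halogen, and in this assay this place on the aromatic ring, para to a large group, gives a clearly higher number with it than with two of the halogens: the change from bromo gives (a number 32 percentage points higher from compound 3 to compound 4 (beyond the scatter)) and the change from fluoro gives (a number 25 percentage points higher from compound 1 to compound 4 (beyond the scatter)). Chloro keeps the top number, as the change to nitro gives (a number 23 percentage points lower from compound 2 to compound 4 (beyond the scatter)). A high number at this place is therefore not confined to chloro, although no group shown exceeds it.

From the compounds shown here alone, whether an amine, a carboxylic acid or a methoxy group at this place would fall with chloro, with nitro or with the two lower halogens stays open. So does whether nitro would keep its standing at other doses or times in the same test. Nothing given here bears on why these groups differ.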